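This account rests on a few compounds, and the source may have more. Where it says the series, first, only, none or still open, it means among the compounds named here.

In a functional assay on SW480 cells (Homo sapiens) for cytotoxicity, read by MTT assay, with a stated time of 4 days (a lower number here means a stronger inhibitor, a higher number a weaker inhibitor), the measured compounds read:
compound 1 `C=C1C(=O)[C@]23C[C@@]1(O)CC[C@H]2c1ccc(O)c(C)c1[C@@H]3Cn1cc(-c2ccccn2)nn1` gives 410 nM;
compound 2 `C=C1C(=O)[C@]23C[C@@]1(O)CC[C@H]2c1ccc(O)c(C)c1[C@@H]3Cn1cc(-c2ccc(C(F)(F)F)cc2)nn1` gives 370 nM;
compound 3 `COc1ccc(-c2cn(C[C@H]3c4c(ccc(OS(=O)(=O)c5ccc(C)cc5)c4C)[C@@H]4CC[C@@]5(C)C[C@]43CC5=O)nn2)cc1` reaches only a measurement limit, > 20000 nM.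

Of the two plain numbers, compound 2 holds the lower one, with compound 1 close by and the gap within the scatter. Compound 4 `C=C1C(=O)[C@]23C[C@@]1(O)CC[C@H]2c1ccc(O)c(C)c1[C@@H]3Cn1cc(-c2ccc(OC)cc2)nn1` differs from compound 2 by methoxy in place of trifluoromethyl on an aromatic carbon. Going by the values given here, one measured step bears on this kind of change, the swap of the aryl group a 1.1-fold lower number from compound 1 to compound 2 (0.04 log units; within the scatter), which left the number essentially where it was. Compound 3 carries the same 4-methoxyphenyl but also a different core, so its limit says little about the aryl group on its own. The expected step is therefore a 1.1-fold higher number from compound 2 to compound 4 (0.03 log units; within the scatter), nothing beyond the scatter. Compound 4 is estimated at 400 nM, between 150 nM and 1200 nM.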

Compound 4, half-maximal inhibitory concentration: 220 nM
Estimate against measurement, compound 4: 1.8-fold (0.26 log units) above, and the stated range covers the measured number.
By their numbers in this assay, from the lowest: compounds 4, 2 and 1 (each within the scatter of the next). At a limit, above all of these: compound 3.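

In this assay, the exchange of trifluoromethyl for methoxy reads a 1.7-fold lower number from compound 2 to compound 4 (0.23 log units; within the scatter), and the exchange of the whole aryl group reads a 1.9-fold lower number from compound 1 to compound 4 (0.27 log units; within the scatter). A group with a hydrogen-bond acceptor thus replaces one without, and the scatter still cannot separate the two numbers. Going by these compounds alone, compounds 1, 2 and 4 therefore show three different aryl groups on the shared core, with no step among them beyond the scatter.

Nothing measured here gives a reason for these numbers. On these data alone, whether an amine or a carboxylic acid on this ring, or a longer chain in place of methoxy, would move the number beyond the scatter stays open.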